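A few compounds are considered here, and "the series" means these few. Any claim that something is new, unique, unknown or untested is made for them only; others in the source may bear on it.

Measured compounds:
compound 1 `CN(C)CCN(CCN(C)C)c1ccc(C(=O)N2CCc3ccc(OS(N)(=O)=O)cc3C2)cc1` gives 15.9%
compound 2 `NS(=O)(=O)Oc1ccc2c(c1)CN(C(=O)c1ccc(N3CCC(N4CCCCC4)CC3)cc1)CC2` gives 53.7%
compound 3 `CCN(Cc1ccc(Br)cc1)c1ccc(C(=O)N2CCc3ccc(OS(N)(=O)=O)cc3C2)cc1` gives 95.9%

In an assay on HEK293 cells for inhibition of Steryl-sulfatase (Homo sapiens), tested at 1 uM (a lower number here means a weaker effect, a higher number a stronger effect of the compound at the concentration tested), compound 3 stands highest of the three; compound 2 is nearest, and compound 1 furthest, both beyond the scatter. Among the measured compounds shown here, the only single-place step among the measured compounds is a number 80 percentage points higher from compound 1 to compound 3 (beyond the scatter), a large rise when bis(2-(dimethylamino)ethyl)amino is exchanged for (4-bromobenzyl)(ethyl)amino on an aromatic carbon. Compound 4 `NS(=O)(=O)Oc1ccc2c(c1)CN(C(=O)c1ccc(N3CCCCC3)cc1)CC2` has not yet been measured in this assay. It differs from compound 3 in one place: piperidin-1-yl in place of (4-bromobenzyl)(ethyl)amino on an aromatic carbon. For the measured compounds named here, no measured step covers exactly this exchange. Compound 2, which carries a different piperidine-containing group at the same place, shows a lower number than compound 3, and compound 1, with bis(2-(dimethylamino)ethyl)amino, lower still, so the loss of the (4-bromobenzyl)(ethyl)amino group is expected to cost some inhibition. Compound 4 is therefore estimated to fall between compound 2 and compound 3, at 60% with a range of 30% to 88%, which means an expected step of a number 35.9 percentage points lower from compound 3 to compound 4 (beyond the scatter).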

Compound 4, a percentage reported as inhibition, at one concentration (the size of the read-out at that concentration, not a potency): 38.3%
Beside the measured number, compound 4's estimate is 21.7 percentage points above it, and the stated range covers the measured number.
By their numbers in this assay, from the lowest: compound 1; then compound 4; then compound 2; then compound 3.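

In this assay, the place on the aromatic carbon, para to a large group, proves sensitive to the exchange of (4-bromobenzyl)(ethyl)amino for piperidin-1-yl, with a number 57.6 percentage points lower from compound 3 to compound 4 (beyond the scatter). The piperidine ring alone does not restore the number: hydrogen in place of piperidin-1-yl on the saturated ring carbon gives a number 15.4 percentage points lower from compound 2 to compound 4 (beyond the scatter), so the outer ring of compound 2 adds to inhibition at this place. Even so, the plain piperidin-1-yl group outperforms bis(2-(dimethylamino)ethyl)amino, with a number 22.4 percentage points higher from compound 1 to compound 4 (beyond the scatter). From the compounds shown here alone, it remains open whether the 4-bromobenzyl part or the ethyl chain matters more in compound 3, and how a morpholine ring or a 4-chlorobenzyl group would fare at this place. Nothing measured here accounts for these steps.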